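The compounds below may be only part of what the source reports. "The series", "measured", "known", "first", "only" and "open" are said of these compounds alone.

Measured compounds:
Compound 1 `ClCc1ccccc1Cn1cnc2c(Cl)nc(Cl)nc21`: 4160 nM
Compound 2 `ClCc1ccccc1Cn1cnc2c(Cl)ncnc21`: 10900 nM
Compound 3 `ClCc1ccccc1Cn1cnc2ncnc(Cl)c21`: 24500 nM

All three were tested in a functional assay on SF-268 cells (Homo sapiens) for cytotoxicity, read by sulforhodamine B assay, with a stated time of 48 h; a lower number here means a stronger inhibitor of growth, a higher number a weaker inhibitor of growth. Compound 1 and compound 2 share a core and differ in one place, and the step from the second to the first is a 2.6-fold lower number from compound 2 to compound 1 (0.42 log units; beyond the scatter); the change behind it is chloro in place of hydrogen on an aromatic carbon. Compound 3 gives the highest of the three numbers, and its core differs from that of compound 2 in a way that is not broken down here.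

Compound 4 `ClCc1ccccc1Cn1cnc2nc(Cl)nc(Cl)c21` has not yet been measured. For the measured compounds named here, it differs from compound 3 by chloro in place of hydrogen on an aromatic carbon, the same change as the one from compound 2 to compound 1, in a place that is described in the same words in both cases. The expected outcome rests on compound 3 at 24500 nM and on the size of a 2.6-fold lower number from compound 2 to compound 1 (0.42 log units; beyond the scatter). In this assay compound 4 is therefore expected to give about 9400 nM, with a likely range from 4000 nM to 22000 nM. The step that this estimate means is a 2.6-fold lower number from compound 3 to compound 4 (0.42 log units; beyond the scatter).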

Compound 4, concentration for total growth inhibition: 24500 nM
The estimate for compound 4 lay 2.6-fold (0.42 log units) below the measured number; the measured number lies above the stated range.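

In this assay, chloro in place of hydrogen on an aromatic carbon gave no change at the digits printed from compound 3 to compound 4 (within the scatter), whereas on the other core the same change had given a 2.6-fold lower number from compound 2 to compound 1 (0.42 log units; beyond the scatter). Set side by side, the two steps cannot be told apart: the same change on two cores in this assay, a 2.6-fold lower number (0.42 log units; beyond the scatter) from compound 2 to compound 1 and no change at the digits printed (within the scatter) from compound 3 to compound 4, 2.6-fold (0.42 log units) apart, within the scatter of two such steps The pair therefore does not show that the core alters the effect of this change, and it does not show that the size of the step carries reliably from one core to the other, as it rests on only two steps.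

The compounds shown leave open how an amine or a methoxy group in place of the chloro group on either core would compare with hydrogen in this assay. They also leave open whether replacing the chloromethyl group shared by all four compounds with a hydroxymethyl group would change the number, and whether the chloro step would then look the same.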